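The source may report more compounds than this note shows. Statements on the series, on what has been measured and on what is new or still open speak of the compounds shown alone.

Measured compounds

compound 1 `CCCCOC(=O)Nc1ccc([Se]C#N)cc1` — in a functional assay on PC-3 cells (Homo sapiens) for cytotoxicity, read by MTT assay, with a stated time of 72 h (a higher number here means a weaker inhibitor of growth, a lower number a stronger inhibitor of growth), compound 1 gives 12400 nM
compound 2 `O=C(Nc1ccc([Se][Se]c2ccc(NC(=O)Oc3ccc(F)cc3)cc2)cc1)Oc1ccc(F)cc1` — in this assay compound 2 gives 4900 nM

Compound 1 stands at the highest of the two numbers. Its nearest neighbour is compound 2, which gives a lower number, and that gap lies beyond the scatter. Among the measured compounds shown here, compound 2 shares no single-point change with compound 1, so no step between the two can be read as a structural effect; the two values only show where each stands.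

Compound 3 `N#C[Se]c1ccc(NC(=O)OCc2ccccc2)cc1` has not been measured in this assay. It differs from compound 1 in one place: phenyl in place of propyl on a saturated chain carbon bound to an oxygen next to a carbonyl group. For the measured compounds named here, the change sits on the carbamate side of the shared core, away from the selenocyanate, and no measured pair shows what such an exchange does in this assay. The expectation is therefore a step of modest size at most, with no clear direction, most likely within the scatter.

On that basis compound 3 is estimated at 9000 nM, with a range from 3000 nM to 30000 nM; the expected step is a 1.4-fold lower number from compound 1 to compound 3 (0.14 log units; within the scatter).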

Compound 3, concentration for 50% growth inhibition: 3700 nM
Compound 3: middle estimate off by 2.4-fold (0.39 log units), on the high side, and the stated range covers the measured number.
By their numbers in this assay, from the lowest: compounds 3 and 2 (each within the scatter of the next); then compound 1.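

The carbamate side of the shared core proves responsive in this assay: phenyl in place of propyl on a saturated chain carbon bound to an oxygen next to a carbonyl group gives a 3.4-fold lower number from compound 1 to compound 3 (0.53 log units; beyond the scatter). Among the compounds shown here, this is the first step that can be read as a structural effect, and it shows that this exchange alone moves the number beyond the scatter while the selenocyanate stays unchanged. No measurement at hand bears on the origin of this step.

A single step cannot separate the effect of the aromatic ring from that of the higher carbon count, and a cyclohexyl group or a longer chain such as hexyl on the same carbon would be needed to tell the two apart. Also open, on these data alone, is whether an amine or a carboxylic acid on the phenyl ring of compound 3 would move the number further, and whether the step holds with a diselenide in place of the selenocyanate, since compound 2 differs from compound 1 and from compound 3 in more than one place and gives no readable step.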